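Hydroxy Group Joins a Series Sitting at the Assay Limit

This account rests on a few compounds, and the source may have more. Where it says the series, first, only, none or still open, it means among the compounds named here.

Compound 1 `COc1ccc(C(=O)/C=C/c2ccc(-n3ccnc3)cc2)c2c1C=CC(C)(C)O2` gives > 10000 nM in a functional assay on HepG2 cells (Homo sapiens) for antiproliferative activity, read by MTT assay, with a stated time of 24 h; a higher number here means a weaker inhibitor, a lower number a stronger inhibitor. Compound 2 `COc1ccc(C(=O)/C=C/c2ccc(C(F)(F)F)cc2)c2c1C=CC(C)(C)O2` gives > 10000 nM in this assay. Compound 3 `COc1ccc(C(=O)/C=C/c2ccccc2)c2c1C=CC(C)(C)O2` gives > 10000 nM in this assay.

The value of compound 1 is a limit of the assay and not a number. The value of compound 2 is likewise a limit. The value of compound 3 is also a limit, so compound 3 stands nowhere that can be ranked against the other two; all three share (the limit of > 10000 nM in this assay, at which 3 of the 3 values shown sit).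

The three compounds differ only in the group on one aromatic carbon, and the steps between them are a step that the two limits leave unreadable from compound 1 to compound 2, a step that the two limits leave unreadable from compound 1 to compound 3 and a step that the two limits leave unreadable from compound 2 to compound 3. Compound 4 `COc1ccc(C(=O)/C=C/c2ccc(O)cc2)c2c1C=CC(C)(C)O2` changes the same carbon once more: hydroxy in place of hydrogen on an aromatic carbon. These measured steps bear on the change but give no readable size, so no direction beyond the scatter can be expected from them.

The estimated step is a step that the limit leaves unreadable from compound 3 to compound 4, and compound 4 is expected to give 15000 nM, within 4000 nM to 60000 nM.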

Compound 4, half-maximal inhibitory concentration: > 10000 nM
Compound 4: only a limit was reported; the forecaster's own chance of this, stated with the estimate: 80%; the middle value lies beyond the limit too.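

Going by these compounds alone, compound 4 also gives only a limit and not a number, as do compound 1, compound 2 and compound 3, so no step among them can be read: the limit of > 10000 nM in this assay, at which 4 of the 4 values shown sit. The compounds shown leave open whether any group on this aromatic carbon changes the result, and how strong each compound really is.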